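Pentyl in place of hydrogen on selenium in a pyridopyrimidine series

This account rests on a few compounds, and the source may have more. Where it says the series, first, only, none or still open, it means among the compounds named here.

For the measured compounds named here, compound 2 `Nc1nc([SeH])nc2ncccc12` is the only member of this set with a single number in a functional assay on HT-29 cells (Homo sapiens) for cytotoxicity, read by MTT assay, with a stated time of 72 h (on this read-out higher numbers stand for weaker inhibition of growth and lower numbers for stronger inhibition of growth), where compound 2 gives 36300 nM. Compound 1 `CCCCC[Se]c1nc([Se]CCCCC)c2cccnc2n1` carries two pentyl groups on selenium; in this assay compound 1 reaches only a limit of > 100000 nM. Compound 3 `[SeH]c1nc([SeH])c2cccnc2n1` has no single number in this assay, where compound 3 is recorded as "not determined" (no result reported). Compound 4 `CCCCC[Se]c1nc(N)c2cccnc2n1` differs from compound 2 by pentyl in place of hydrogen on a selenium. Going by the values given here, no step between two measured compounds is available, but compound 1 shows that two such pentyl groups leave the growth inhibition at a limit, as recorded in the limit of > 100000 nM in this assay, at which 1 of the 3 values shown sits. Compound 4 is therefore expected to inhibit growth more weakly than compound 2, by a step of a 2.2-fold higher number from compound 2 to compound 4 (0.34 log units; beyond the scatter) that likely exceeds the scatter. Compound 4 is estimated at 80000 nM, within 25000 nM to 250000 nM.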

Compound 4, concentration for 50% growth inhibition: 5910 nM
Estimate against measurement, compound 4: 14-fold (1.13 log units) above, outside the stated range (below it).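

In this assay, pentyl in place of hydrogen on a selenium strengthens growth inhibition rather than weakening it, with a 6.1-fold lower number from compound 2 to compound 4 (0.79 log units; beyond the scatter). With one nitrogen atom in place of the second pentyl-on-selenium group on an aromatic carbon, the record shows an at least 16-fold lower number from compound 1 to compound 4 (1.22 log units; beyond the scatter), so a single pentyl on selenium gives a measurable number where two do not. That second step starts from a limit, not a number: the limit of > 100000 nM in this assay, at which 1 of the 4 values shown sits.

The compounds shown leave open whether an ethyl group or a longer chain such as octyl on the selenium would shift the number further. They also leave open how a benzyl group there would compare.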